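Isoflavone ether acids: chain length and monoamine oxidase inhibition

This account rests on a few compounds, and the source may have more. Where it says the series, first, only, none or still open, it means among the compounds named here.

Measured so far:
- compound 1 `O=C(O)CCCCCCCOc1ccc2c(=O)c(-c3ccc(O)cc3)coc2c1`, in an assay (Cricetulus griseus) for inhibition of Monoamine oxidase (Homo sapiens) (a lower number here means a stronger inhibitor, a higher number a weaker inhibitor), compound 1 gives 6500 nM.
- compound 2 `CCCCCCC(Oc1ccc2c(=O)c(-c3ccc(O)cc3)coc2c1)C(=O)OCC`; in this assay compound 2 gives >> 9000 nM, which is a limit of the assay and not a number.

Among the compounds with values here, compound 1 holds the only number in this assay; the other value shown is the limit at which compound 2 sits, as in the limit of >> 9000 nM in this assay, at which 1 of the 2 values shown sits. Within the data shown here, no pair of measured compounds differs in one place, so no measured step is available.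

Compound 3 `O=C(O)COc1ccc2c(=O)c(-c3ccc(O)cc3)coc2c1` differs from compound 1 by carboxy in place of 6-carboxyhexyl on a saturated chain carbon bound to an oxygen on an aromatic ring. Among the measured compounds shown here, with the measured compounds giving no step to lean on, the direction of this change cannot be read from the data; a step beyond the scatter in either direction is possible. The expectation for compound 3 is 12000 nM, within 2500 nM to 60000 nM, which is estimated to mean a step of a 1.8-fold higher number from compound 1 to compound 3 (0.27 log units; within the scatter).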

Compound 3, half-maximal inhibitory concentration: >> 9000 nM
Compound 3 gave a limit, no number (the forecaster's own chance of this, stated with the estimate: 40%); the middle value lies beyond the limit too.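

Within the data shown here, this is the first measured step at this position: in this assay, carboxy in place of 6-carboxyhexyl on a saturated chain carbon bound to an oxygen on an aromatic ring gives an at least 1.3-fold higher number from compound 1 to compound 3 (0.14 log units; that floor lies within the scatter). Compound 3 gives >> 9000 nM, which is a limit of the assay and not a number, so the step has a direction but only a floor for its size, and that floor does not establish a change beyond the scatter. Of the compounds shown, only compound 1, with the 6-carboxyhexyl group, gives a number in this assay, while the rest stand at a limit: the limit of >> 9000 nM in this assay, at which 2 of the 3 values shown sit.

From the compounds shown here alone, how far compound 3 lies past its limit remains open. Also open, going by these compounds, is whether a longer chain, or a chain ending in an amine, would give a number in this assay.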